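This account rests on a few compounds, and the source may have more. Where it says the series, first, only, none or still open, it means among the compounds named here.

Measured compounds in a functional assay on CHO cells for agonist activity at Glucose-dependent insulinotropic receptor (Homo sapiens), read by cAMP accumulation; on this read-out lower numbers stand for an effect already at smaller amounts and higher numbers for an effect only at larger amounts of compound:
- compound 1 `CCS(=O)(=O)c1ccc(COC[C@@H]2C[C@@H]2C2CCN(c3nc(C(C)C)no3)CC2)c(F)c1`: 0.8 nM
- compound 2 `CCc1cnc(N2CCC([C@H]3C[C@H]3COCc3ccc(S(C)(=O)=O)cn3)CC2)nc1`: 1.5 nM
- compound 3 `CC(C)c1noc(N2CCC([C@H]3C[C@H]3COCc3ccc(S(C)(=O)=O)cc3F)CC2)n1`: 4.2 nM

Compound 3 stands at the highest of the three numbers; compound 2 lies nearer to it, compound 1 furthest. For the measured compounds named here, the only step that is counted, a 5.3-fold higher number from compound 1 to compound 3 (0.72 log units; beyond the scatter), concerns the chain on the sulfonyl sulfur, the same part of the molecule that is now exchanged.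

Compound 4 `CC(C)c1noc(N2CCC([C@H]3C[C@H]3COCc3ccc(-n4cnnn4)cc3F)CC2)n1` differs from compound 3 by 1H-tetrazol-1-yl in place of methylsulfonyl on an aromatic carbon.

Going by the values given here, no measured pair shows this exchange, so the direction rests only on the observation that the one counted step at this site was beyond the scatter. A modest rise in the number is expected for compound 4, a 2.4-fold higher number from compound 3 to compound 4 (0.38 log units; beyond the scatter), with wide uncertainty. The estimate for compound 4 is 10 nM, within 2.5 nM to 40 nM.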

Compound 4, half-maximal effective concentration: 1.7 nM
Estimate against measurement, compound 4: 5.9-fold (0.77 log units) above; measured number outside the range, below it.
By their numbers in this assay, from the lowest: compounds 1, 2 and 4 (each within the scatter of the next, the first and the last beyond it); then compound 3.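

In this assay the aromatic carbon para to a large group accepts a ring in place of a sulfonyl group: 1H-tetrazol-1-yl gives a 2.5-fold lower number from compound 3 to compound 4 (0.39 log units; beyond the scatter) against methylsulfonyl. Against ethylsulfonyl the same group gives a 2.1-fold higher number from compound 1 to compound 4 (0.33 log units; beyond the scatter) and the two sulfonyl compounds thus lie on either side of compound 4. No measurement here offers an explanation for either step.

Still open, on these data alone, is how a carboxylic acid, a primary amide or a nitrile would fare on this carbon. Also open, as far as these compounds go, is whether 1H-tetrazol-1-yl gives a similar step on the core of compound 2.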